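The compounds below may be only part of what the source reports. "The series", "measured", "known", "first", "only" and "open" are said of these compounds alone.

Compound 1 `O/N=C(/Nc1cccc(F)c1)c1ccc2occc2c1`: 32700 nM
Compound 2 `OCc1cc2cc(/C(=N\O)Nc3cccc(F)c3)ccc2o1`: 1700 nM
Compound 3 `OCc1cc2cc(/C(=N\O)Nc3cccc(Cl)c3)ccc2o1`: 8000 nM

In an assay on isolated protein for inhibition of Indoleamine 2,3-dioxygenase 1 (Homo sapiens), read by spectrophotometry (on this read-out higher numbers stand for weaker inhibition and lower numbers for stronger inhibition), compound 2 gives the lowest of the three numbers, with compound 3 next at a 4.7-fold higher number from compound 2 to compound 3 (0.67 log units; beyond the scatter) and compound 1 furthest at a 19-fold lower number from compound 1 to compound 2 (1.28 log units; beyond the scatter). Compound 4 `COCc1cc2cc(/C(=N\O)Nc3cccc(F)c3)ccc2o1` differs from compound 2 by methyl in place of hydrogen on an oxygen on a saturated carbon. Within the data shown here, no measured pair shows this exact change. Among the measured compounds shown here, the only step touching the same position is that from compound 1 to compound 2, a large gain upon introducing the hydroxymethyl group, a 19-fold lower number from compound 1 to compound 2 (1.28 log units; beyond the scatter). Capping that group with a methyl removes part of what made that step, so a modest rise in the number is expected for compound 4, a 2.9-fold higher number from compound 2 to compound 4 (0.47 log units; beyond the scatter). The estimate for compound 4 in this assay is 5000 nM, within 1500 nM to 16000 nM.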

Compound 4, half-maximal inhibitory concentration: 7100 nM
Compound 4: middle estimate off by 1.4-fold (0.15 log units), on the low side, within the range that was stated.
By their numbers in this assay, from the lowest: compound 2; then compounds 4 and 3 (each within the scatter of the next); then compound 1.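

In this assay the hydroxymethyl hydrogen on oxygen proves to matter, as methyl in its place raises the number (a 4.2-fold higher number from compound 2 to compound 4 (0.62 log units; beyond the scatter)) and gives back part of the gain from hydroxymethyl. Methoxymethyl still keeps a real advantage over hydrogen on the aromatic carbon (a 4.6-fold lower number from compound 1 to compound 4 (0.66 log units; beyond the scatter)), so the capped group retains part of that gain.

The compounds shown leave open how an aminomethyl group, a carboxylic acid or a longer chain such as hydroxyethyl would fare here, and whether methoxymethyl costs the same with the chloro group of compound 3. No measurement shown explains the effect of this methyl.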